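A few compounds are considered here, and "the series" means these few. Any claim that something is new, unique, unknown or untested is made for them only; others in the source may bear on it.

In a functional assay on IGROV-1 cells (Homo sapiens) for inhibition, read by sulforhodamine B assay, with a stated time of 48 h (on this read-out lower numbers stand for stronger inhibition of growth and higher numbers for weaker inhibition of growth), compound 1 `N#Cc1c(-c2nnc(O)c3nn(-c4ccccc4)cc23)nn(-c2ccccc2)c1-c1ccccc1` gives 92200 nM and compound 2 `N#Cc1c(-c2nnc(O)c3nn(-c4ccc(Cl)cc4)cc23)nn(-c2ccccc2)c1-c1ccccc1` gives 91300 nM, so these two stand level. Compound 3 `N#Cc1c(-c2nnc(-c3ccccc3)c3nn(-c4ccc(Cl)cc4)cc23)nn(-c2ccccc2)c1-c1ccccc1` has phenyl in place of hydroxy on an aromatic carbon. Going by the values given here, the only measured step, a 1.0-fold lower number from compound 1 to compound 2 (0.00 log units; within the scatter), is chloro in place of hydrogen, a different change, so no measurement speaks directly to this one. A moderate move is nonetheless expected, and the estimated step is a 3.0-fold lower number from compound 2 to compound 3 (0.48 log units; beyond the scatter), an uncertain guess. For compound 3 the expected value is 30000 nM, with an estimated range of 5000 nM to 100000 nM overall.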

Compound 3, concentration for 50% growth inhibition: 93400 nM
Estimate against measurement, compound 3: 3.1-fold (0.49 log units) below; low and high end bracket the measured number.
By their numbers in this assay, from the lowest: compounds 2, 1 and 3 (each within the scatter of the next).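

In this assay, the step with phenyl in place of hydroxy on an aromatic carbon, next to the ring nitrogen, is a 1.0-fold higher number from compound 2 to compound 3 (0.01 log units; within the scatter). This position therefore carries phenyl, with its six-membered aromatic ring and no hydrogen-bond donor or acceptor, and compound 3 stands level with compound 2, which carries hydroxy. No measurement at hand accounts for this result. On these data alone, whether an amine, a carboxylic acid or a longer chain at this position would also stand level remains open.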